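This account rests on a few compounds, and the source may have more. Where it says the series, first, only, none or still open, it means among the compounds named here.

Measured so far in this series:

- compound 1 `Cc1cc(-c2ccccc2NCC2=NCCN2)on1`: 38.9 nM
- compound 2 `Cc1cccnc1-c1ccccc1NCC1=NCCN1`: 24.6 nM

In a functional assay for activation of Alpha-1A adrenergic receptor (Homo sapiens), read by calcium flux (a lower number here means that less compound is needed, a higher number that more compound is needed for the effect), compound 1 gives 38.9 nM, the higher of the two numbers. Compound 2 gives 24.6 nM; the gap between the two lies within the scatter, so the two compounds are not separated on this read-out.

Compound 3 `CCO/N=C(\C)c1ccccc1NCC1=NCCN1` is not yet measured. It differs from compound 1 by a group of 6 heavy atoms (4 carbon, 1 nitrogen, 1 oxygen; no ring) in place of a group of 6 heavy atoms (4 carbon, 1 nitrogen, 1 oxygen; one five-membered aromatic ring with 2 hetero atoms), on an aromatic carbon. For the measured compounds named here, no step between measured compounds shows what this kind of change does here, so the expectation rests on compound 1 alone, with only the shared core as common ground.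

With both measured compounds close together and nothing in the data to set a direction, the step of a 1.4-fold higher number from compound 1 to compound 3 (0.15 log units; within the scatter) is expected to stay within the scatter, with a slight lean towards a higher number. For compound 3 the half-maximal effective concentration is estimated at 55 nM, within 15 nM to 200 nM.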

Compound 3, half-maximal effective concentration: 52.5 nM
Compound 3: middle estimate off by 1.0-fold (0.02 log units), on the high side; low and high end bracket the measured number.
By their numbers in this assay, from the lowest: compounds 2, 1 and 3 (each within the scatter of the next, the first and the last beyond it).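

In this assay the change at this aromatic carbon gives a 1.3-fold higher number from compound 1 to compound 3 (0.13 log units; within the scatter) and so stays within the scatter. At this position, the 3-methyl-1,2-oxazol-5-yl ring can be replaced by an open-chain group with no ring and a double bond outside aromatic rings, with the same count of heavy atoms and hydrogen-bond acceptors, without separating the two compounds on this read-out. No measurement in hand accounts for this result.

From the compounds shown here alone, both groups are the same size by heavy-atom count, so the effect of a markedly smaller or larger group at this carbon remains open. Going by these compounds, whether an amine or a carboxylic acid there, or a saturated ethoxyalkyl chain in place of the double-bond-containing group, would give a step beyond the scatter also remains open.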